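Carbamate chain length in the selenocyanate series

The compounds below may be only part of what the source reports. "The series", "measured", "known", "first", "only" and "open" are said of these compounds alone.

Compound 1 `CCCOC(=O)Nc1ccc([Se]C#N)cc1` and compound 2 `CCOC(=O)Nc1ccc([Se][Se]c2ccc(NC(=O)OCC)cc2)cc1` have both been run in a functional assay on MCF7 cells (Homo sapiens) for cytotoxicity, read by MTT assay, with a stated time of 72 h; a higher number here means a weaker inhibitor of growth, a lower number a stronger inhibitor of growth. Compound 1 gives 34400 nM, the smaller of the two numbers shown, and compound 2 gives 39000 nM; the gap between them is within the scatter, so no order between the two can be claimed. Compound 3 `CCOC(=O)Nc1ccc([Se]C#N)cc1` has not yet been measured in this assay. It differs from compound 1 by hydrogen in place of methyl on a saturated chain carbon, two bonds along the chain from an oxygen next to a carbonyl group; cut one bond further out, the change reads propoxy to ethoxy. Among the compounds with values here, no measured pair shows this change, so its size has no precedent here. The expectation is that the step from compound 1 to compound 3, a 1.0-fold higher number from compound 1 to compound 3 (0.01 log units; within the scatter), stays within the scatter, with no fixed direction. Compound 3 is thus expected to give about 35000 nM, between 15000 nM and 80000 nM.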

Compound 3, concentration for total growth inhibition: 36700 nM
Beside the measured number, compound 3's estimate is 1.0-fold (0.02 log units) below it; the range from low to high includes it.
By their numbers in this assay, from the lowest: compounds 1, 3 and 2 (each within the scatter of the next).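

In this assay, within the data shown here, the change from propoxy to ethoxy gives a 1.1-fold higher number from compound 1 to compound 3 (0.03 log units; within the scatter) and is the only measured pair showing hydrogen in place of methyl on a saturated chain carbon, two bonds along the chain from an oxygen next to a carbonyl group. With the selenocyanate held fixed, this shortening of the chain therefore produces no difference that can be told from the scatter. No evidence on the reason for this result is at hand.

Among these compounds, this single pair covers only the step from propyl to ethyl, so it cannot show whether the flat result extends to other chain lengths. As far as these compounds go, whether a longer chain such as butyl, a branched chain such as isopropyl, or a chain ending in an amine or a carboxylic acid would shift the number remains open.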